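Swapping one group on compound 2

The source may report more compounds than this note shows. Statements on the series, on what has been measured and on what is new or still open speak of the compounds shown alone.

Compound 2 `COc1ccc([C@@H]2C/C(=N/OCc3cn(-c4cccc(CO)c4)nn3)c3cc(CC=C(C)C)c(OC)cc3O2)cc1` gives 43% in a functional assay on A549 cells (Homo sapiens) for inhibition, read by sulforhodamine B assay, with a stated time of 48 h, tested at 50 uM (on this read-out lower numbers stand for less inhibition of growth and higher numbers for more inhibition of growth at the one concentration tested), and stands level, within the usual scatter, with the two other measured compounds. Compound 1 `COc1ccc([C@@H]2C/C(=N/OCc3cn(-c4ccc(O)cc4)nn3)c3cc(CC=C(C)C)c(OC)cc3O2)cc1` gives 52% and compound 3 `C#CCOc1ccc([C@@H]2CC(=O)c3cc(CC=C(C)C)c(OC)cc3O2)cc1` gives 53% in this assay as well.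

The next compound, compound 4 `COc1ccc([C@@H]2C/C(=N/OCc3cn(-c4ccc(NC(C)=O)cc4)nn3)c3cc(CC=C(C)C)c(OC)cc3O2)cc1` carries 4-acetamidophenyl in place of 3-(hydroxymethyl)phenyl on an aromatic nitrogen and keeps the rest of the molecule unchanged. Going by the single measured change at this place a number 9 percentage points lower from compound 1 to compound 2 (within the scatter) with 3-(hydroxymethyl)phenyl in place of 4-hydroxyphenyl on an aromatic nitrogen, no shift beyond the scatter is expected in this assay for the new group. Among the measured compounds shown here, one step is thin evidence, and no measured compound carries 4-acetamidophenyl yet. The expected step is a number 5 percentage points higher from compound 2 to compound 4 (within the scatter) and it remains only an estimate. The estimated range for compound 4 runs from 36% to 60% around an expected 48% as the middle value.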

Compound 4, percent growth inhibition at one concentration: 19%
The estimate for compound 4 lay 29 percentage points above the measured number, and the stated range ends above it.
By their numbers in this assay, from the lowest: compound 4; then compounds 2, 1 and 3 (each within the scatter of the next).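

Among the compounds shown here, the position on the aromatic nitrogen does respond in this assay: the earlier swap there stayed within the scatter, but 4-acetamidophenyl gives a number 24 percentage points lower from compound 2 to compound 4 (beyond the scatter) and is the first change at this place to go beyond it. The comparison with the hydroxy compound gives a number 33 percentage points lower from compound 1 to compound 4 (beyond the scatter), a large step from exchanging only hydroxy for acetamido on an aromatic carbon, while the counted hydrogen-bond donors and acceptors do not separate 3-(hydroxymethyl)phenyl from 4-acetamidophenyl. No measurement here accounts for the loss of growth inhibition.

On these data alone, it remains open whether the whole acetamido group matters or only part of it. An amine or a carboxylic acid on the same aromatic carbon could show whether growth inhibition returns towards that of compound 1 or stays near that of compound 4.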